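The source may report more compounds than this note shows. Statements on the series, on what has been measured and on what is new or still open speak of the compounds shown alone.

In a functional assay on LNCaP cells (Homo sapiens) for antiproliferative activity (on this read-out lower numbers stand for stronger inhibition and higher numbers for weaker inhibition), compound 3 `Cn1ncc(Cl)c1-c1cc(C(=O)N[C@@H]2CN[C@H](CCN3CCCC3)C[C@H]2c2ccc(Cl)c(Cl)c2)oc1Cl` gives 1920 nM as the highest of the two numbers available. Compound 1 `CNC(=O)C[C@@H]1C[C@@H](c2ccc(Cl)c(Cl)c2)[C@H](NC(=O)c2cc(-c3c(Cl)cnn3C)c(Cl)o2)CN1` stands lower at 40 nM on the same core, while compound 2 `CCC[C@@H]1C[C@@H](c2ccc(Cl)c(Cl)c2)[C@H](NC(=O)c2cc(-c3c(Cl)cnn3C)c(Cl)o2)CN1` shows "not determined" (no result reported) as its entry and adds no number. Compound 4 `COCC[C@@H]1C[C@@H](c2ccc(Cl)c(Cl)c2)[C@H](NC(=O)c2cc(-c3c(Cl)cnn3C)c(Cl)o2)CN1` is still unmeasured and departs from compound 3 by methoxy in place of pyrrolidin-1-yl on a saturated chain carbon, two bonds along the chain from a saturated ring carbon. Going by the values given here, the one measured step that bears on this is a 48-fold higher number from compound 1 to compound 3 (1.68 log units; beyond the scatter) and it is large and beyond the scatter. That step brought in the pyrrolidin-1-yl group, which compound 4 gives up again, though with methoxy and not the methylcarbamoyl of compound 1 in its place. Among the compounds with values here, a large move to a lower number is therefore expected, but no measured step covers methoxy itself, and the range is kept wide. The expected step is a 16-fold lower number from compound 3 to compound 4 (1.20 log units; beyond the scatter) on this estimate. In this assay the estimate for compound 4 is 120 nM with an expected range from 30 nM to 600 nM around it.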

Compound 4, half-maximal inhibitory concentration: 250 nM
Estimate against measurement, compound 4: 2.1-fold (0.32 log units) below, within the range that was stated.
By their numbers in this assay, from the lowest: compound 1; then compound 4; then compound 3.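

In this assay, going by these compounds alone, the change to methoxy at this saturated chain carbon gives a 7.7-fold lower number from compound 3 to compound 4 (0.89 log units; beyond the scatter) and so shows that compound 1's methylcarbamoyl is not the only group that gives a lower number than the 2-(pyrrolidin-1-yl)ethyl chain of compound 3. Methoxy recovers only part of that gap, as the change from methylcarbamoyl to methoxymethyl gives a 6.3-fold higher number from compound 1 to compound 4 (0.80 log units; beyond the scatter) and leaves compound 1 with the lowest number of the three. Nothing measured here explains either step.

The compounds shown leave open whether a primary amine or a carboxylic acid at the end of this chain would stand nearer to compound 1 or to compound 3. They also leave open whether a longer chain ending in methoxy would keep the number of compound 4.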